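Adding a Methyl to a Well-Tolerated Compound

This account rests on a few compounds, and the source may have more. Where it says the series, first, only, none or still open, it means among the compounds named here.

In an ADME assay on HEK293 cells (Homo sapiens) for cytotoxicity, read by resazurin assay, with a stated time of 24 h (a higher number here means that more compound is tolerated, a lower number that less compound is tolerated), compound 2 (`CCN(CC)C(=O)c1c(O)cccc1CCc1ccc2ccccc2c1`) gives > 100000 nM, which is a limit of the assay and not a number. Compound 3 (`CCN(CC)C(=O)c1c(CCc2ccc3ccccc3c2)cccc1OC`), not yet measured, differs from it by methyl in place of hydrogen on an oxygen on an aromatic ring, or hydroxy to methoxy. Compound 1 (`CCN(CC)C(=O)c1c(CCc2ccc3ccccc3c2)cc(OC)cc1OC`), which also carries methoxy, gives > 100000 nM, again a limit. Among the measured compounds shown here, no measured step exists to guide the expectation in this assay, so the expected change, a number no higher from compound 2 to compound 3 (the limit leaves the size open), is none beyond the scatter. For compound 3, the estimated value is 100000 nM, with an expected range of 50000 nM to 200000 nM.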

Compound 3, half-maximal cytotoxic concentration: 85700 nM
The estimate for compound 3 lay 1.2-fold (0.07 log units) above the measured number; measured number inside the range.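

Among the compounds shown here, compound 3 gives the first true number in this assay, so methyl in place of hydrogen on an oxygen on an aromatic ring now has a step: an at least 1.1-fold lower number from compound 2 to compound 3 (0.06 log units; that floor lies within the scatter). Hydrogen in place of methoxy on an aromatic carbon also has one: an at least 1.1-fold lower number from compound 1 to compound 3 (0.06 log units; that floor lies within the scatter). Both steps are only floors, not full sizes, because compound 1 and compound 2 each give a limit and not a number: the limit of > 100000 nM in this assay, at which 2 of the 3 values shown sit.

From the compounds shown here alone, the true size of either step stays open. So does what a longer chain, or a chain ending in an amine, on that oxygen would do in this assay.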